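Isopropyl in Place of Dimethoxypropyl on the Ring Nitrogen

A few compounds are considered here, and "the series" means these few. Any claim that something is new, unique, unknown or untested is made for them only; others in the source may bear on it.

Of the compounds shown here, three have been measured in a functional assay on NCI-H460 cells (Homo sapiens) for antiproliferative activity, read by CCK-8 assay, with a stated time of 72 h, tested at 8 uM; on this read-out lower numbers stand for a weaker effect and higher numbers for a stronger effect at the one concentration tested. Compound 1, `Nc1ccccc1NC(=O)c1ccc(Cn2cnc3c(Nc4cccc(OC(F)(F)F)c4)nc(Cl)nc32)cc1`, gives 62.4%. Compound 2, `COC(CCn1cnc2c(NCc3ccc(C(=O)Nc4ccccc4N)cc3)nc(Cl)nc21)OC`, gives 51.2%. Compound 3, `CC(C)n1cnc2c(Nc3ccccc3)nc(NCOCc3ccc(/C=C/C(=O)Nc4ccccc4N)cc3)nc21`, gives 53.1%. Compound 2 stands below compound 1 by a margin that exceeds the scatter, while the number for compound 3 lies within the scatter of that for compound 2, so no order between those two can be read.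

The unmeasured compound 4, `CC(C)n1cnc2c(NCc3ccc(C(=O)Nc4ccccc4N)cc3)nc(Cl)nc21`, differs from compound 2 in one place: isopropyl in place of 3,3-dimethoxypropyl on an aromatic nitrogen. For the measured compounds named here, no pair of measured compounds differs only by this change, so its effect in this assay is not known from the data. Compound 3 also carries an isopropyl on its aromatic nitrogen, but it differs from compound 2 elsewhere as well, so it cannot serve as a reference. A step of no more than the scatter is expected, in either direction. Compound 4 is therefore estimated to give about 54% in this assay, in the range 40% to 68%; the expected step of a number 2.8 percentage points higher from compound 2 to compound 4 (within the scatter) is small.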

Compound 4, a percentage reported as inhibition, at one concentration (the size of the read-out at that concentration, not a potency): 80.5%
Compound 4: middle estimate off by 26.5 percentage points, on the low side; the whole stated range lies below it.
By their numbers in this assay, from the lowest: compounds 2, 3 and 1 (each within the scatter of the next, the first and the last beyond it); then compound 4.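

On the ring nitrogen, isopropyl in place of 3,3-dimethoxypropyl gives a number 29.3 percentage points higher from compound 2 to compound 4 (beyond the scatter) in this assay and so shows that this position is not indifferent to its substituent. The earlier compounds shown here could not show this, since none of them formed a pair differing in this one place. The step comes with a smaller group, with 3 heavy atoms in place of 7 and no hydrogen-bond acceptors in place of 2, but nothing available explains it.

For the compounds shown here, the single change alters chain length, branching and oxygen content together, so a plain propyl chain or a 3-methoxypropyl group would be needed to tell these apart. Going by these compounds, whether a larger branched group such as cyclopentyl, or a terminal amine or carboxylic acid, would be tolerated on this nitrogen remains open.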